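The source may hold more compounds than are shown below. What is called first, only, known or untested is meant among the compounds shown, and "the series" means these compounds.

Measured so far in a functional assay on A549 cells (Homo sapiens) for inhibition, read by sulforhodamine B assay, with a stated time of 72 h; a higher number here means a weaker inhibitor of growth, a lower number a stronger inhibitor of growth

- compound 1 `CCOC(=O)/C=C/c1ccncc1-c1ccc2c(ccn2C)c1` gives 1720 nM
- compound 2 `Cn1ccc2cc(-c3cnccc3/C=C/C(=O)O)ccc21` gives > 10000 nM (a limit of the assay)
- compound 3 `O=C(O)CCc1ccncc1-c1ccc2ccccc2c1` gives > 10000 nM (a limit of the assay)

Compound 2 has no number, only a limit. Its position on the scale is the limit of > 10000 nM in this assay, at which 2 of the 3 values shown sit.

The next compound is compound 4 `CNC(=O)/C=C/c1ccncc1-c1ccc2c(ccn2C)c1`. The change is methylamino in place of hydroxy on a carbonyl carbon. The carboxy group of compound 2 thus becomes methylcarbamoyl, and the rest of the structure stays the same.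

Going by the values given here, only one measured step bears on this change, at the same carbonyl: an at least 5.8-fold higher number from compound 1 to compound 2 (0.76 log units; beyond the scatter). Read in reverse, it shows that capping the carboxy group as the ethyl ester gives a measurable value, as compound 1 gives 1720 nM. That step is an ester-to-acid change, not an amide change, so it offers only a partial guide. As far as these compounds go, its size is also open-ended, since one end is a limit.

In this assay a lower number is therefore expected for compound 4, beyond the scatter, though a second limit remains possible. The expected change is an at least 2.8-fold lower number from compound 2 to compound 4 (0.45 log units; beyond the scatter). The estimate for compound 4 is 3500 nM, with an expected range of 1000 nM to 10000 nM.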

Compound 4, concentration for 50% growth inhibition: 6450 nM
Estimate against measurement, compound 4: 1.8-fold (0.27 log units) below; the range from low to high includes it.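

Compound 2 carries only a limit of the assay in this assay, > 10000 nM. Methylamino on the carbonyl carbon brings the series back onto the measured scale, so the ethyl ester is no longer the only replacement of the hydroxy that gives a number, but the step reads an at least 1.5-fold lower number from compound 2 to compound 4 (0.19 log units; that floor lies within the scatter), and the true size of this change remains unfixed. The new comparison between the two capped forms at the same carbonyl carbon is better defined, at a 3.8-fold higher number from compound 1 to compound 4 (0.57 log units; beyond the scatter), so in this pair methylamino gives the weaker inhibitor of growth, and an amide at this position does not match the ethyl ester.

The compounds shown leave open how far this order extends to other groups on the same carbonyl carbon, such as a plain amino group, dimethylamino, or an alkoxy group with a longer chain. They also leave open what the 2-(methylcarbamoyl)ethenyl chain contributes relative to a saturated propanamide chain on the same core, since compound 3 differs from these compounds in more than one place.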